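This account rests on a few compounds, and the source may have more. Where it says the series, first, only, none or still open, it means among the compounds named here.

Compound 1 `O=C(N[C@H]1CCC[C@H](NC(=O)c2cnccn2)C1)c1cccc(Cl)c1`: 1370 nM
Compound 2 `O=C(N[C@@H]1CCC[C@H](NC(=O)c2ccccn2)C1)c1cccc(Cl)c1`: 1510 nM
Compound 3 `Cc1cccc(C(=O)N[C@H]2CCC[C@H](NC(=O)c3ccccn3)C2)c1`: 1000 nM

All three were tested in a functional assay on HEK293 cells for antagonist activity at metabotropic glutamate receptor 5 (Homo sapiens), read by FLIPR and calcium flux; a higher number here means a weaker inhibitor, a lower number a stronger inhibitor. Compound 1 holds the second highest of the three numbers, but its gaps to compound 2 and to compound 3 both lie within the usual scatter, so no order among them can be read from these values. Compound 4 `Cc1cccnc1C(=O)N[C@H]1CCC[C@H](NC(=O)c2cccc(Cl)c2)C1` has not yet been measured. It differs from compound 1 in one place: 3-methylpyridin-2-yl in place of pyrazin-2-yl on a carbonyl carbon. Among the compounds with values here, no measured pair isolates such a change, and the three measured compounds sit at similar values although their aromatic amide groups differ. The expected step is therefore small, a 1.4-fold lower number from compound 1 to compound 4 (0.14 log units; within the scatter), with nothing beyond the scatter anticipated. Compound 4 is estimated to give about 1000 nM in this assay, with a likely range from 400 nM to 2500 nM.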

Compound 4, half-maximal inhibitory concentration: 7840 nM
Compound 4: middle estimate off by 7.8-fold (0.89 log units), on the low side; measured number above the stated range.
By their numbers in this assay, from the lowest: compounds 3, 1 and 2 (each within the scatter of the next); then compound 4.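

In this assay, within the data shown here, the group on this carbonyl carbon turns out to matter: 3-methylpyridin-2-yl in place of pyrazin-2-yl gives a 5.7-fold higher number from compound 1 to compound 4 (0.76 log units; beyond the scatter), the only step here that isolates one change. The earlier compounds shown here offered no pair differing in one place, and their values could not show that this position responds to such a change. Nothing measured here accounts for the step.

Still open, as far as these compounds go, is whether the step follows from the added methyl or from the ring nitrogen that leaves. Also open, from the compounds shown here alone, is how a methoxy or a dimethylamino group on this aromatic ring would read.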